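Bromo in place of fluoro: compound 3 to compound 4

A few compounds are considered here, and "the series" means these few. Any claim that something is new, unique, unknown or untested is made for them only; others in the source may bear on it.

Three compounds have numbers in a functional assay on HCT-116 cells (Homo sapiens) for antiproliferative activity, read by sulforhodamine B assay, with a stated time of 48 h; on this read-out higher numbers stand for weaker inhibition and lower numbers for stronger inhibition. Compound 3 (`COc1cc(OC)c(C(=O)/C=C/c2ccc(F)cc2)c(OCC=C(C)C)c1`) gives 3200 nM. Compound 2 (`COc1cc(OC)c(C(=O)/C=C/c2ccc(OC)c(OC)c2)c(OCC=C(C)C)c1`) gives 5700 nM, within the scatter of compound 3. Compound 1 (`COc1cc(O)c(C(=O)/C=C/c2ccc(Br)cc2)c(OC)c1`) gives 14000 nM, a weaker result than compound 3 and beyond the scatter.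

Compound 4 (`COc1cc(OC)c(C(=O)/C=C/c2ccc(Br)cc2)c(OCC=C(C)C)c1`) differs from compound 3 by bromo in place of fluoro on an aromatic carbon, para to a large group. Among the measured compounds shown here, one measured step bears on this aromatic group: a 1.8-fold lower number from compound 2 to compound 3 (0.25 log units; within the scatter). That step replaces 3,4-dimethoxyphenyl with 4-fluorophenyl and stays within the scatter. For the measured compounds named here, the 4-bromophenyl group also occurs in compound 1, but the core of compound 1 differs, so no measured pair isolates bromo against fluoro.

On these data alone, no change beyond the scatter is therefore expected in this assay, and the direction remains open. The expected size of the change is a 1.1-fold higher number from compound 3 to compound 4 (0.04 log units; within the scatter). The estimate for compound 4 is 3500 nM, with an expected range of 1600 nM to 8000 nM.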

Compound 4, half-maximal inhibitory concentration: 2100 nM
Compound 4: middle estimate off by 1.7-fold (0.22 log units), on the high side; the measured number falls inside the stated range.
By their numbers in this assay, from the lowest: compounds 4, 3 and 2 (each within the scatter of the next, the first and the last beyond it); then compound 1.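

In this assay the exchange of 4-fluorophenyl for 4-bromophenyl gives a 1.5-fold lower number from compound 3 to compound 4 (0.18 log units; within the scatter) and so leaves this aromatic carbon tolerant of either halogen. Compound 4 nevertheless stands apart from the 3,4-dimethoxyphenyl analogue, with a 2.7-fold lower number from compound 2 to compound 4 (0.43 log units; beyond the scatter) as a modest step, whereas the fluoro analogue stayed within the scatter of that compound. Among the compounds shown here, on the 4-bromophenyl background, 3-methylbut-2-en-1-yl in place of hydrogen on an oxygen on an aromatic ring gives a 6.7-fold lower number from compound 1 to compound 4 (0.82 log units; beyond the scatter) as a second modest step, the first single-change reading at that oxygen.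

No measurement on hand accounts for any of these steps. On these data alone, whether an amine or a carboxylic acid on this aromatic carbon, or a longer chain in place of 3-methylbut-2-en-1-yl, would give a step beyond the scatter remains open.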